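Acid to Benzyl Amide: Expected Shift in Cytotoxicity

The source may report more compounds than this note shows. Statements on the series, on what has been measured and on what is new or still open speak of the compounds shown alone.

Of the compounds shown here, three have so far been measured in an ADME assay on HEp-2 cells (Homo sapiens) for cytotoxicity; on this read-out higher numbers stand for lower toxicity in this test and lower numbers for higher toxicity in this test. Compound 1 `O=C1CSc2ccccc2N1Cc1nc2ccccc2n1CCCCF` reaches only a limit of this assay, > 96300 nM. Compound 3 `CN1C(=O)N(Cc2nc3ccccc3n2CCCCF)c2ccccc2S1(=O)=O` gives 87700 nM in this assay. Compound 2 `CC(C)CCn1c(CN2C(=O)C(CC(=O)O)c3ccccc32)nc2ccccc21` gives 16500 nM, the lower of the two numbers, with compound 3 standing higher by a gap beyond the usual scatter.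

Compound 4 `CC(C)CCn1c(CN2C(=O)C(CC(=O)NCc3ccccc3)c3ccccc32)nc2ccccc21` differs from compound 2 in one place: benzylamino in place of hydroxy on a carbonyl carbon. Among the measured compounds shown here, no measured pair of compounds shares this change, so its effect in this assay is untested. For the measured compounds named here, no step of this kind is available, so the account rests on expectation alone: a modest step toward lower numbers is expected, a 1.8-fold lower number from compound 2 to compound 4 (0.26 log units; within the scatter), with a number rather than a limit. Compound 4 is thus estimated at about 9000 nM, between 3000 nM and 30000 nM.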

Compound 4, half-maximal cytotoxic concentration: 720 nM
Compound 4: middle estimate off by 13-fold (1.10 log units), on the high side, outside the stated range (below it).
By their numbers in this assay, from the lowest: compound 4; then compound 2; then compound 3. At a limit, above all of these: compound 1.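

The position on a carbonyl carbon proves highly sensitive in this assay: benzylamino in place of hydroxy gives a 23-fold lower number from compound 2 to compound 4 (1.36 log units; beyond the scatter) and a clear move toward higher toxicity in this test. Among the compounds shown here, this is the first measured step at this position, and it shows that a free carboxy group is not required for cytotoxicity. Nothing measured here gives a cause for the step.

From the compounds shown here alone, it remains open whether the amide or the benzyl ring accounts for the shift. A plain amino group or a methylamino group on the same carbonyl would separate the two.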